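The source may hold more compounds than are shown below. What is called first, only, known or untested is meant among the compounds shown, and "the series" means these compounds.

Measured so far in a functional assay on the whole organism with Mus musculus as the target, at a dose of 150 mg/kg by the oral route; a lower number here means that less compound is needed, a higher number that more compound is needed for the effect:
Compound 1 `Cc1nnc(NC(N)=O)cc1Cc1ccccc1` gives 12.5 mg/kg.
Compound 2 `Cc1nn2cnnc2cc1Cc1ccccc1` gives 25 mg/kg.

Compound 2 stands at the upper end of these two numbers, but compound 1 lies within the usual scatter of it, so the pair cannot be told apart. Compound 3 `Cc1nn2c(N)nnc2cc1Cc1ccccc1` differs from compound 2 in one place: amino in place of hydrogen on an aromatic carbon. Among the measured compounds shown here, no measured pair shows what such an amino does here, so there is no basis for a direction. The step is expected to stay within the scatter: a 1.1-fold lower number from compound 2 to compound 3 (0.06 log units; within the scatter). Compound 3 is estimated at 22 mg/kg in this assay, with a range from 8 mg/kg to 60 mg/kg.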

Compound 3, dose for half-maximal effect: 14 mg/kg
Compound 3: the middle estimate sits 1.6-fold (0.20 log units) above what was measured, and the stated range covers the measured number.
By their numbers in this assay, from the lowest: compounds 1, 3 and 2 (each within the scatter of the next).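

Amino in place of hydrogen on an aromatic carbon, between two ring nitrogen atoms, is the first change at this position that can be read in this assay, and it amounts to a 1.8-fold lower number from compound 2 to compound 3 (0.25 log units; within the scatter). The position therefore carries an amino group with no difference that can be told from the scatter. Nothing available bears on this result.

Still open, as far as these compounds go, is whether a methylamino group, a hydroxyl or a carboxylic acid on this carbon would move the number beyond the scatter. Whether any group here can do so also remains unanswered.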